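This account rests on a few compounds, and the source may have more. Where it says the series, first, only, none or still open, it means among the compounds named here.

Working notes on the series. For the measured compounds named here, compound 1 `O=C1CN(C2CCCC2)c2nc(Nc3ccc(N4CCCCC4)cn3)ncc2N1` is the only member with a number: in a functional assay on HT-29 cells (Homo sapiens) for inhibition, read by MTT assay, with a stated time of 48 h (on this read-out lower numbers stand for stronger inhibition and higher numbers for weaker inhibition), compound 1 gives 21100 nM. Compound 2 `CC1CCN(c2ccc(Nc3ncc4c(n3)N(C3CCCC3)CC(=O)N4)nc2)CC1` gives only a limit in this assay, > 30000 nM. That limit is recorded as the limit of > 30000 nM in this assay, at which 1 of the 2 values shown sits. Compound 3 `CCN1C(=O)CN(C2CCCC2)c2nc(Nc3ccc(N4CCCCC4)cn3)ncc21` remains to be measured in this assay. Its change from compound 1 is ethyl in place of hydrogen on an amide-type nitrogen in a ring. Going by the values given here, the single measured step, an at least 1.4-fold higher number from compound 1 to compound 2 (0.15 log units; that floor lies within the scatter), touches a different place, a saturated ring carbon, and adds a methyl rather than an ethyl; it gives no direction beyond the scatter. Among the compounds with values here, no measured step bears directly on the amide-type ring nitrogen. Within the data shown here, with both measured values weak and the one comparison flat, compound 3 is expected to stay weak, the step being a 1.2-fold higher number from compound 1 to compound 3 (0.07 log units; within the scatter), no larger than the scatter. For compound 3 the estimate in this assay is 25000 nM, in the range 8000 nM to 80000 nM.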

Compound 3, half-maximal inhibitory concentration: 22000 nM
Beside the measured number, compound 3's estimate is 1.1-fold (0.06 log units) above it, and the stated range covers the measured number.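

For the compounds shown here, the first measured step on the amide-type nitrogen in a ring, ethyl in place of hydrogen, shows no readable change in this assay: a 1.0-fold higher number from compound 1 to compound 3 (0.02 log units; within the scatter). The amide hydrogen of compound 1 can therefore be given up at this position, and the added ethyl, with its 2 carbon atoms, leaves compound 3 at a number within the scatter of compound 1. This does not separate the position from the rest of the series, and compound 2 still gives a limit rather than a number: the limit of > 30000 nM in this assay, at which 1 of the 3 values shown sits.

From the compounds shown here alone, it remains open whether a longer chain ending in an amine or a carboxylic acid on this nitrogen would move the number in this assay beyond the scatter. Also open, going by these compounds, is whether a methyl group in place of the cyclopentyl group would do so.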